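This account rests on a few compounds, and the source may have more. Where it says the series, first, only, none or still open, it means among the compounds named here.

Compound 1 `CCCNC(=O)c1cc(-n2cc(-c3ccccc3)nn2)ccc1O` and compound 2 `O=C(c1cc(-n2cc(-c3ccccc3)nn2)ccc1O)N1CCCCC1` share one core, while compound 3 `CCCNC(=O)c1ccc(-n2cc(-c3cc(C(F)(F)F)cc(C(F)(F)F)c3)nn2)cc1O` and compound 4 `O=C(c1ccc(-n2cc(-c3cc(C(F)(F)F)cc(C(F)(F)F)c3)nn2)cc1O)N1CCCCC1` share another; how the two cores differ is not broken down here. In a functional assay on RAW264.7 cells (Mus musculus) for inhibition, read by Griess assay, with a stated time of 20 h (a lower number here means a stronger inhibitor, a higher number a weaker inhibitor), compound 1 gives only a limit, > 20000 nM. Compound 2 likewise gives only a limit in this assay, > 20000 nM. The change piperidin-1-yl in place of propylamino on a carbonyl carbon therefore produces a step that the two limits leave unreadable from compound 1 to compound 2. Compound 3 also gives only a limit in this assay, > 20000 nM. The same change, (piperidin-1-yl in place of propylamino on a carbonyl carbon), leads from compound 3 to compound 4. Among the measured compounds shown here, because the limit of > 20000 nM in this assay, at which 3 of the 3 values shown sit, no measured step is readable, and the step is expected to be a step that the limit leaves unreadable from compound 3 to compound 4. Compound 4 is accordingly estimated at 30000 nM in this assay, with a range from 10000 nM to 100000 nM, and is expected most likely to be reported once more only as a limit.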

Compound 4, half-maximal inhibitory concentration: > 20000 nM
Compound 4: only a limit was reported; the forecaster's own chance of this, stated with the estimate: 85%; the middle value is on the limit's open side.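

Compound 3 and compound 4 both give only a limit in this assay, so no step can be read between them: the limit of > 20000 nM in this assay, at which 4 of the 4 values shown sit.

The compounds shown leave open whether piperidin-1-yl in place of propylamino alters inhibition at all on either core.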